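A Ring Replaces the Amino Alcohol on the Alkyne

This account rests on a few compounds, and the source may have more. Where it says the series, first, only, none or still open, it means among the compounds named here.

Compound 2 `COc1cc[nH]c1/C=C1\C(=O)Nc2ccc(F)c(C#C[C@H](N)CO)c21` gives 270 nM in a functional assay on SW480 cells (Homo sapiens) for inhibition (a lower number here means a stronger inhibitor, a higher number a weaker inhibitor), the second highest of the three numbers seen so far. Compound 1 `COc1cc[nH]c1/C=C1\C(=O)Nc2ccc(F)c(C#C[C@@H](C)O)c21` gives 130 nM, while compound 3 `COc1cc[nH]c1/C=C1\C(=O)Nc2ccc(F)c(C#C[C@H](CO)NCCO)c21` gives 967 nM. The step of a 2.1-fold higher number from compound 1 to compound 2 (0.32 log units; beyond the scatter) and the step of a 3.6-fold higher number from compound 2 to compound 3 (0.55 log units; beyond the scatter) both show the number rising as the group on the triple-bonded carbon grows, and the step of a 7.4-fold higher number from compound 1 to compound 3 (0.87 log units; beyond the scatter) spans the two. Compound 4 `COc1cc[nH]c1/C=C1\C(=O)Nc2ccc(F)c(C#CC3(O)CCOCC3)c21` differs from compound 2 in one place: 4-hydroxyoxan-4-yl in place of 1-amino-2-hydroxyethyl on a triple-bonded carbon. Of the three measured compounds, compound 4 most resembles compound 1, whose value is 130 nM. A modest fall is therefore expected, a 1.8-fold lower number from compound 2 to compound 4 (0.26 log units; within the scatter). Compound 4 is estimated at 150 nM, with a range from 50 nM to 450 nM.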

Compound 4, half-maximal inhibitory concentration: 290 nM
Estimate against measurement, compound 4: 1.9-fold (0.29 log units) below; the range from low to high includes it.
By their numbers in this assay, from the lowest: compound 1; then compounds 2 and 4 (each within the scatter of the next); then compound 3.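

On the triple-bonded carbon, the ring of 4-hydroxyoxan-4-yl, which has no nitrogen, and the open 1-amino-2-hydroxyethyl chain read alike in this assay (a 1.1-fold higher number from compound 2 to compound 4 (0.03 log units; within the scatter)), so among these compounds the amine is not needed to reach this level. The ring still falls short of 1-hydroxyethyl (a 2.2-fold higher number from compound 1 to compound 4 (0.35 log units; beyond the scatter)) yet clearly improves on the group with the 2-hydroxyethyl amine (a 3.3-fold lower number from compound 3 to compound 4 (0.52 log units; beyond the scatter)), which shows that a ring is tolerated at this position. Nothing given here explains these differences. The compounds shown leave open how a piperidine ring, which carries a nitrogen in place of the ring oxygen, would compare at this position.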